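Adding a Carbon to a Hydroxyalkyl Chain

The source may hold more compounds than are shown below. What is called first, only, known or untested is meant among the compounds shown, and "the series" means these compounds.

Four compounds share a core, shown for compound 1 as `NS(=O)(=O)c1ccc(S(=O)(=O)CCO)c(F)c1` and for compound 3 as `NS(=O)(=O)c1ccc(S(=O)(=O)CCCO)c(F)c1`. In a physicochemical assay for solubility, at pH 7.4 (a lower number here means a less soluble compound, a higher number a more soluble compound), compound 1 gives 3300 ug/mL, and compound 3 gives 6600 ug/mL. The change between them is hydroxymethyl in place of hydroxy on a saturated chain carbon, two bonds along the chain from a sulfonyl sulfur, and the step it made was a 2.0-fold higher number from compound 1 to compound 3 (0.30 log units; within the scatter). Compound 2, `NS(=O)(=O)c1ccc(SCCCO)c(F)c1`, gives 900 ug/mL in this assay, the lowest of the three numbers; how its core differs from that of compound 1 is not broken down here. Compound 4, `NS(=O)(=O)c1ccc(SCCCCO)c(F)c1`, has not yet been measured. It differs from compound 2 by hydroxymethyl in place of hydroxy on a saturated chain carbon, three bonds along the chain from a sulfur, the same kind of change as that from compound 1 to compound 3, though the place differs: there the carbon lay two bonds along the chain from a sulfonyl sulfur, here three bonds along the chain from a sulfur. Resting on the step of a 2.0-fold higher number from compound 1 to compound 3 (0.30 log units; within the scatter), the step from compound 2 to compound 4 in this assay is expected to be no change at the digits printed from compound 2 to compound 4 (within the scatter). Compound 4 is therefore estimated at 900 ug/mL, with a likely range from 400 ug/mL to 2000 ug/mL.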

Compound 4, solubility: 1000 ug/mL
Compound 4: the middle estimate sits 1.1-fold (0.05 log units) below what was measured; low and high end bracket the measured number.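

In this assay, the new step is a 1.1-fold higher number from compound 2 to compound 4 (0.05 log units; within the scatter), and the step on the other core was a 2.0-fold higher number from compound 1 to compound 3 (0.30 log units; within the scatter). Read together, they show that hydroxymethyl in place of hydroxy stayed within the scatter both with the chain on a sulfonyl sulfur and with the chain on a sulfur, so across these two pairs the result of the change carried from one core to the other. This rests on two pairs alone and does not show that the change would stay within the scatter on any other core, and nothing given here explains why these steps came out as they did.

The compounds shown leave open whether a chain longer than 4-hydroxybutyl would also stay within the scatter of its shorter partner in this assay. They also leave open what an amine or a carboxylic acid in place of the hydroxy would do on either core.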